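Replacing the Amine on the Thiocarbonyl Carbon

The source may hold more compounds than are shown below. What is called first, only, known or untested is meant among the compounds shown, and "the series" means these compounds.

Three compounds share one core and differ only in the amine attached to a thiocarbonyl carbon. In a functional assay on HeLa cells (Homo sapiens) for antiproliferative activity, read by CCK-8 assay, with a stated time of 72 h, tested at 2 uM (a higher number here means a stronger effect of the compound at the concentration tested, a lower number a weaker effect), compound 1 `Nc1ccccc1NC(=O)c1ccc(CSC(=S)N2CCc3ccccc32)cc1` gives 38%. Compound 2 `Nc1ccccc1NC(=O)c1ccc(CSC(=S)N2CCCc3ccccc32)cc1` gives 26.1% in this assay. Compound 3 `CCN(Cc1ccncc1)C(=S)SCc1ccc(C(=O)Nc2ccccc2N)cc1` gives 63.5%, the highest of the three, with a number 25.5 percentage points higher from compound 1 to compound 3 (beyond the scatter) and a number 37.4 percentage points higher from compound 2 to compound 3 (beyond the scatter), while the two ring amines differ by a number 11.9 percentage points lower from compound 1 to compound 2 (beyond the scatter).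

Compound 4 `CC1CCN(C(=S)SCc2ccc(C(=O)Nc3ccccc3N)cc2)CC1` is the next step: 4-methylpiperidin-1-yl in place of ethyl((pyridin-4-yl)methyl)amino on a thiocarbonyl carbon. Both earlier ring amines on this carbon gave lower numbers than compound 3, so a fall is expected, roughly a number 23.5 percentage points lower from compound 3 to compound 4 (beyond the scatter). In this assay compound 4 is estimated at 40%, likely between 25% and 57%.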

Compound 4, a percentage reported as inhibition, at one concentration (the size of the read-out at that concentration, not a potency): 46.8%
Compound 4: middle estimate off by 6.8 percentage points, on the low side; low and high end bracket the measured number.
By their numbers in this assay, from the lowest: compound 2; then compounds 1 and 4 (each within the scatter of the next); then compound 3.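

Moving from ethyl((pyridin-4-yl)methyl)amino to 4-methylpiperidin-1-yl gives a number 16.7 percentage points lower from compound 3 to compound 4 (beyond the scatter) in this assay and leaves compound 3 the highest of the four. The ring amines do not all sit equally low: a number 20.7 percentage points higher from compound 2 to compound 4 (beyond the scatter) shows a real gain over 1,2,3,4-tetrahydroquinolin-1-yl. Yet a number 8.8 percentage points higher from compound 1 to compound 4 (within the scatter) means that 4-methylpiperidin-1-yl and 2,3-dihydro-1H-indol-1-yl cannot be told apart.

As far as these compounds go, whether benzyl(ethyl)amino, with a benzene ring in place of the pyridine, would keep the number of compound 3 remains open. No measurement shown explains these differences.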